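Chloro to bromo in the series

The compounds below may be only part of what the source reports. "The series", "measured", "known", "first", "only" and "open" are said of these compounds alone.

In a functional assay on L1210 cells (Mus musculus) for antiproliferative activity, read by cell counting, with a stated time of 2 days (on this read-out higher numbers stand for weaker inhibition and lower numbers for stronger inhibition), compound 1 `COc1ccc(C(=O)c2sc(Nc3ccccc3)nc2N)cc1OC` gives > 10000 nM, which is a limit of the assay and not a number. Compound 2 `COc1ccc(Nc2nc(N)c(C(=O)c3ccccc3)s2)cc1` gives 850 nM, and compound 3 `COc1ccc(Nc2nc(N)c(C(=O)c3ccc(Cl)cc3)s2)cc1` gives 84 nM, the lower of the two numbers available.

Compound 4 `COc1ccc(Nc2nc(N)c(C(=O)c3ccc(Br)cc3)s2)cc1` is still unmeasured. It differs from compound 3 by bromo in place of chloro on an aromatic carbon, with bromo in place of chloro on an aromatic carbon, para to a large group.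

Among the compounds with values here, only one measured step bears on this change: a 10-fold lower number from compound 2 to compound 3 (1.01 log units; beyond the scatter), where chloro replaced hydrogen at the same place. Within the data shown here, no measured step exchanges chloro for another group, so the size of that step does not carry over directly to this assay. Compound 4 is therefore expected to stay close to compound 3, with no change beyond the scatter.

The expected step is a 1.2-fold lower number from compound 3 to compound 4 (0.08 log units; within the scatter).

For compound 4 the estimated value is 70 nM, with an expected range from 25 nM to 200 nM.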

Compound 4, half-maximal inhibitory concentration: 110 nM
Compound 4: the middle estimate sits 1.6-fold (0.20 log units) below what was measured, within the range that was stated.
By their numbers in this assay, from the lowest: compounds 3 and 4 (each within the scatter of the next); then compound 2. At a limit, above all of these: compound 1.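

In this assay the change from 4-chlorophenyl to 4-bromophenyl gives a 1.3-fold higher number from compound 3 to compound 4 (0.12 log units; within the scatter) and so, at this position, the two halogens cannot be told apart. Bromo in place of hydrogen gives a 7.7-fold lower number from compound 2 to compound 4 (0.89 log units; beyond the scatter) and so the lower number is no longer tied to chloro alone: both halogens at this place stand clearly under the number of compound 2. Nothing measured here gives a reason for this result.

From the compounds shown here alone, whether a halogen is needed at this place remains open, since a methyl group, an amine or a carboxylic acid there could show whether the lower number extends beyond chloro and bromo. Also open, going by these compounds, is how fluoro or iodo would compare at the same place, and whether the same change would hold on a different substitution pattern of the shared core.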